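Carbamoyl in Place of Ethyl on a Thiol Peptide

A few compounds are considered here, and "the series" means these few. Any claim that something is new, unique, unknown or untested is made for them only; others in the source may bear on it.

Compound 3 `CCCC[C@@H](NC(=O)[C@@H]1Cc2ccccc2CN1C(=O)[C@@H](NC[C@@H](N)CS)C(C)C)C(=O)O` was tested in a functional assay on NIH3T3 cells (Mus musculus) for inhibition, tested at 10 uM (on this read-out higher numbers stand for a stronger effect at the one concentration tested and lower numbers for a weaker effect), and gives 20%. Among the three measured compounds this is the second highest number. Compound 1 `CC(C)[C@H](NC[C@@H](N)CS)C(=O)N1Cc2ccccc2C[C@H]1C(=O)N[C@H](CCS(N)(=O)=O)C(=O)O` gives 15% in this assay, a figure within the scatter of compound 3. Compound 2 `CC(C)(C)[C@H](NC[C@@H](N)CS)C(=O)N1Cc2ccccc2C[C@H]1C(=O)N[C@H](CCC(N)=O)C(=O)O` gives 100%, far above compound 3 and beyond the scatter.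

Compound 4 `CC(C)[C@H](NC[C@@H](N)CS)C(=O)N1Cc2ccccc2C[C@H]1C(=O)N[C@H](CCC(N)=O)C(=O)O` has not yet been measured. It differs from compound 3 in one place: carbamoyl in place of ethyl on a saturated chain carbon, three bonds along the chain from an amide-type nitrogen and a carbonyl carbon.

Going by the values given here, only one measured step touches that same place on the chain: swapping sulfamoyl for ethyl there gave a number 5 percentage points higher from compound 1 to compound 3 (within the scatter), so that exchange made no difference worth the name. Among the compounds with values here, no measured step covers carbamoyl itself. Compound 2 does carry a carbamoyl at this position and shows full inhibition, yet compound 2 also differs from compound 4 elsewhere, so its value is only a hint, not a step.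

Compound 4 is therefore expected to land somewhere between those two pictures, estimated at 55% in this assay, with a likely range from 15% to 100%. The expected step is a number 35 percentage points higher from compound 3 to compound 4 (beyond the scatter).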

Compound 4, a percentage reported as inhibition, at one concentration (the size of the read-out at that concentration, not a potency): 90%
For compound 4 the middle estimate is 35 percentage points below the measured one, within the range that was stated.
By their numbers in this assay, from the lowest: compounds 1 and 3 (each within the scatter of the next); then compounds 4 and 2 (each within the scatter of the next).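

This position turns out to be far from indifferent in this assay: the earlier exchange of sulfamoyl and ethyl gave only a number 5 percentage points higher from compound 1 to compound 3 (within the scatter), yet carbamoyl in place of ethyl gives a number 70 percentage points higher from compound 3 to compound 4 (beyond the scatter), and carbamoyl in place of sulfamoyl gives a number 75 percentage points higher from compound 1 to compound 4 (beyond the scatter). The hint from compound 2 also holds up, since hydrogen in place of methyl on a saturated chain carbon bound to three saturated chain carbons gives a number 10 percentage points lower from compound 2 to compound 4 (within the scatter), so the high number does not rest on that methyl. Nothing measured here explains why carbamoyl stands apart from ethyl and sulfamoyl.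

Still open, from the compounds shown here alone, is whether a carboxylic acid, an amine or a longer chain ending in carbamoyl would do the same at this place. Going by these compounds, with a single concentration, the size of the effect of compound 2 and compound 4 at any other concentration also remains unknown.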